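The compounds below may be only part of what the source reports. "The series", "measured", "known", "first", "only" and "open" are said of these compounds alone.

Measured so far in an ADME assay for permeability, using PAMPA, with a stated time of 30 min, at pH 7.4; on this read-out lower numbers stand for lower permeability and higher numbers for higher permeability:
- compound 1, `COc1cccc(CNCCCNc2ccnc3cc(Oc4ccc(F)cc4)ccc23)c1O`: 317 10^-6 cm/s
- compound 2, `COc1cccc(Oc2ccc3c(NCCCNCc4cccc(OC)c4O)ccnc3c2)c1`: 317 10^-6 cm/s
- compound 3, `c1coc(CNCCCNc2ccnc3cc(CC4CCCCC4)ccc23)c1`: 23 10^-6 cm/s

Compound 3 stands lowest of the three numbers; compound 1 and compound 2 both lie above it, and in each case the gap is beyond the scatter. Within the data shown here, the only single-point step among the measured compounds is no change at the digits printed from compound 1 to compound 2 (within the scatter), which concerns the group on the oxygen on the aromatic ring and not the side chain.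

Compound 4, `COc1cccc(CNCCCNc2ccnc3cc(CC4CCCCC4)ccc23)c1O`, is obtained from compound 3 by the change (2-hydroxy-3-methoxyphenyl in place of furan-2-yl on a saturated chain carbon bound to an amine nitrogen). Among the measured compounds shown here, no measured step touches this position, so the one step on hand does not bear on it. Compound 1 and compound 2 both carry the entering 2-hydroxy-3-methoxybenzyl group and both give high numbers, but each also differs from compound 3 on the aromatic ring, so their values cannot be read as a clean step for this change. The expectation in this assay is therefore a rise of uncertain size, a 3.0-fold higher number from compound 3 to compound 4 (0.48 log units; beyond the scatter), leaning upward because compound 1 gives 317 10^-6 cm/s with the same entering group. Compound 4 is estimated at 70 10^-6 cm/s, within 18 10^-6 cm/s to 280 10^-6 cm/s.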

Compound 4, apparent permeability: 23 10^-6 cm/s
Beside the measured number, compound 4's estimate is 3.0-fold (0.48 log units) above it, within the range that was stated.
By their numbers in this assay, from the lowest: compounds 3 and 4 (each within the scatter of the next); then compounds 1 and 2 (each within the scatter of the next).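

In this assay the side chain position shows its first clean step: 2-hydroxy-3-methoxyphenyl in place of furan-2-yl on a saturated chain carbon bound to an amine nitrogen gives no change at the digits printed from compound 3 to compound 4 (within the scatter), with cyclohexylmethyl held constant on the shared core. The large gaps now resolve into single-place steps on the aromatic carbon, with cyclohexylmethyl in place of 3-methoxyphenoxy giving a 14-fold lower number from compound 2 to compound 4 (1.14 log units; beyond the scatter) and cyclohexylmethyl in place of 4-fluorophenoxy giving a 14-fold lower number from compound 1 to compound 4 (1.14 log units; beyond the scatter), so among these four compounds the high numbers of compound 1 and compound 2 go with the groups on the aromatic carbon and not with the shared 2-hydroxy-3-methoxybenzyl group. Nothing on hand gives a cause for either the flat step or the large steps.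

Open, going by these compounds, is whether furan-2-yl and 2-hydroxy-3-methoxyphenyl would also read alike with 4-fluorophenoxy or 3-methoxyphenoxy on the aromatic carbon, a comparison that would test the flat step on a second background. Also open, on these data alone, is how an amine or a carboxylic acid on the saturated chain carbon would read in this assay.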